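The compounds below may be only part of what the source reports. "The series", "measured", "known", "first", "only" and "open" are said of these compounds alone.

Of the compounds shown here, three have been measured in a functional assay (aorta) with Oryctolagus cuniculus as the target; a higher number here means weaker binding, a lower number tighter binding. Compound 1 `COc1cc(C(C)=O)ccc1OCCCN1CCC(Cc2ccc(F)cc2)CC1` gives 20 nM in this assay. Compound 2 `COc1cc(C(C)=O)ccc1OCCCN1CCC(C(O)(c2ccc(F)c(F)c2)c2ccc(F)c(F)c2)CC1` gives 2.51 nM, and compound 3 `COc1cc(C(C)O)ccc1OCCCN1CCC(C(c2ccc(F)cc2)c2ccc(F)cc2)CC1` gives 10 nM. Among these three numbers compound 3 holds the second highest place. Its nearest neighbour is compound 1, whose number sits within the usual scatter of the measurement, so the two cannot be told apart in this assay. Compound 2 is the furthest away from compound 3 and has the lower number, by a margin that lies beyond the scatter.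

Compound 4 `Fc1ccc(OCCCN2CCC(C(c3ccc(F)cc3)c3ccc(F)cc3)CC2)cc1` has not yet been measured. It differs from compound 3 in one place: 4-fluorophenyl in place of 4-(1-hydroxyethyl)-2-methoxyphenyl on an oxygen on a saturated carbon. The hydrogen-bond donor and the two acceptors counted for the leaving group are gone, and the entering group carries none. For the measured compounds named here, no pair of measured compounds isolates this change, since compounds 1 and 2 vary elsewhere, so the expectation for compound 4 rests on compound 3 alone. A somewhat higher number is expected for compound 4, a step of a 2.0-fold higher number from compound 3 to compound 4 (0.30 log units; within the scatter) that may well remain within the scatter. The estimated value for compound 4 is 20 nM, with a range from 5 nM to 80 nM.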

Compound 4, dissociation constant: 1.26 nM
Beside the measured number, compound 4's estimate is 16-fold (1.20 log units) above it; measured number below the stated range.
By their numbers in this assay, from the lowest: compounds 4 and 2 (each within the scatter of the next); then compounds 3 and 1 (each within the scatter of the next).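

In this assay, the step of a 7.9-fold lower number from compound 3 to compound 4 (0.90 log units; beyond the scatter) lies beyond the scatter and is the only one in this set that isolates a change in one place. It shows that, on this oxygen on a saturated carbon, a low number does not depend on the hydrogen-bond donor and the two acceptors of 4-(1-hydroxyethyl)-2-methoxyphenyl, since 4-fluorophenyl, with fewer heavy atoms and no donor or acceptor, gives the lower number with the rest of compound 3 unchanged. Nothing measured here bears on why the number falls, so the step stands without an explanation.

The compounds shown leave open which part of the leaving group accounts for the step, since the methoxy and 1-hydroxyethyl groups leave and the fluorine enters in a single exchange. Going by these compounds, whether a plain phenyl or a 4-chlorophenyl on the same oxygen would give a number as low as that of compound 4 also stays open, as does whether the step would carry over to the other groups carried by compound 1 and compound 2.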